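From 4-(Methanesulfonamido)phenyl to (Butylcarbamoyl)methyl

The source may report more compounds than this note shows. Statements on the series, on what has been measured and on what is new or still open speak of the compounds shown alone.

Compound 1 `CC(C)(N)C(=O)N[C@H](COCc1ccccc1)c1nnnn1Cc1ccc(NS(C)(=O)=O)cc1` was examined in an assay on isolated protein for displacement of a labelled ligand from growth hormone secretagogue receptor type 1 (Homo sapiens), with a stated time of 1 h; on this read-out lower numbers stand for stronger inhibition and higher numbers for weaker inhibition. In this assay compound 1 gives > 5000 nM, which is a limit of the measurement and not a number. Compound 2 `CC(C)(N)C(=O)N[C@H](COCc1ccccc1)c1nnn(CC#N)n1` was measured in the same way. In this assay compound 2 gives > 5000 nM, again a limit rather than a number. Among the values shown, compound 1 therefore stands at the limit of > 5000 nM in this assay, at which 2 of the 2 values shown sit, and no measured number places it above or below any other compound.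

Compound 3 `CCCCNC(=O)CCn1nnnc1[C@@H](COCc1ccccc1)NC(=O)C(C)(C)N` has not yet been measured in this assay. It differs from compound 1 in one place: (butylcarbamoyl)methyl in place of 4-(methanesulfonamido)phenyl on a saturated chain carbon bound to an aromatic nitrogen. Within the data shown here, no step between two measured compounds is available to set the size of such a change, and both values shown are limits, so the direction of the change cannot be read from the data. Compound 3 is expected to give about 8000 nM, with a range from 3000 nM to 30000 nM. The expected step from compound 1 to compound 3 is a step that the limit leaves unreadable from compound 1 to compound 3, which is expected to be no change beyond the scatter, and a limit is the most likely report.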

Compound 3, inhibition constant: 2190 nM
Compound 3: middle estimate off by 3.7-fold (0.56 log units), on the high side; measured number outside the range, below it.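

With (butylcarbamoyl)methyl in place of 4-(methanesulfonamido)phenyl, this assay shows an at least 2.2-fold lower number from compound 1 to compound 3 (0.35 log units; beyond the scatter), so the place on a saturated chain carbon bound to an aromatic nitrogen can shift this read-out, which the two limits alone could not show. Among these compounds, in the same read-out compound 3 gives 2190 nM, the only actual number so far, and it comes from a group with no ring, so an aromatic ring at this place is not needed to reach a measurable value on the shared core. As far as these compounds go, the true size of the step remains unknown, as its starting point is a limit and not a number, and compound 2 offers no readable comparison either: the limit of > 5000 nM in this assay, at which 2 of the 3 values shown sit.

What the compounds shown leave open is which part of the (butylcarbamoyl)methyl group carries the change, the amide or the butyl chain. A shorter or longer chain, or an amine or a carboxylic acid in place of the amide, would be needed to tell whether the value moves further in either direction.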